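The compounds below may be only part of what the source reports. "The series", "measured", "known", "first", "only" and "open" are said of these compounds alone.

Measured compounds:
compound 1, `CCOC(=O)N1CCC(=NNC(=O)c2ccc(C(F)(F)F)cc2)CC1`: > 400000 nM
compound 2, `CCOC(=O)N1CCC(=NNC(=O)c2ccc([N+](=O)[O-])cc2)CC1`: > 400000 nM
compound 3, `O=C(NN=C1CC(c2ccccc2)NC(c2ccccc2)C1)c1ccc(C(F)(F)F)cc1`: > 400000 nM

In a toxicity assay on BJ cells (Homo sapiens) for cytotoxicity, read by MTT assay, with a stated time of 24 h (on this read-out lower numbers stand for stronger inhibition and higher numbers for weaker inhibition), compound 1 gives only a limit, > 400000 nM. Compound 2 likewise reaches only a limit in this assay, > 400000 nM. The change between them is nitro in place of trifluoromethyl on an aromatic carbon, and the step that the two limits leave unreadable from compound 1 to compound 2 cannot be read because of the limit of > 400000 nM in this assay, at which 3 of the 3 values shown sit. Compound 3 too stops at a limit in this assay, > 400000 nM. The difference between the core of compound 3 and that of compound 1 is not broken down here. Compound 4, `O=C(NN=C1CC(c2ccccc2)NC(c2ccccc2)C1)c1ccc([N+](=O)[O-])cc1`, is not yet measured; it differs from compound 3 by nitro in place of trifluoromethyl on an aromatic carbon, the same change as that from compound 1 to compound 2. Since that change gave no readable step, and compound 3 already sits at the limit > 400000 nM, compound 4 is expected to show the step that the limit leaves unreadable from compound 3 to compound 4. The estimate for compound 4 in this assay is 500000 nM, between 200000 nM and 2000000 nM.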

Compound 4, half-maximal inhibitory concentration: > 400000 nM
Compound 4: no number, only a limit; the forecaster's own chance of this, stated with the estimate: 85%; the middle value is on the limit's open side.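

No step can be read from compound 3 to compound 4 in this assay, since both values are limits: the limit of > 400000 nM in this assay, at which 4 of the 4 values shown sit. The compounds shown leave open whether nitro and trifluoromethyl differ at all in this cytotoxicity read-out.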